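This account rests on a few compounds, and the source may have more. Where it says the series, first, only, none or still open, it means among the compounds named here.

Measured compounds:
Compound 1 `O=S(=O)(/C=C/c1ccc(Cl)cc1Cl)Cc1ccc(Nc2ncnc3ccccc23)cc1`: 12000 nM
Compound 2 `O=S(=O)(/C=C/c1ccc(O)cc1)Cc1ccc(Nc2ncnc3ccccc23)cc1`: 100000 nM
Compound 3 `O=S(=O)(/C=C/c1ccc(O)cc1)Cc1ccc(Nc2ncnc3ccc(Br)cc23)cc1`: 27000 nM

The three measured compounds were tested in a functional assay on NCI-H520 cells (Homo sapiens); a lower number here means a stronger inhibitor of growth, a higher number a weaker inhibitor of growth. In this assay compound 2 gives 100000 nM, and compound 2 is the starting point for two single changes. One is 2,4-dichlorophenyl in place of 4-hydroxyphenyl on a double-bonded chain carbon bound to a double-bonded chain carbon, which gives compound 1; in this assay compound 1 gives 12000 nM, a step of an 8.3-fold lower number from compound 2 to compound 1 (0.92 log units; beyond the scatter). The other is bromo in place of hydrogen on an aromatic carbon, which gives compound 3; in this assay compound 3 gives 27000 nM, a step of a 3.7-fold lower number from compound 2 to compound 3 (0.57 log units; beyond the scatter). Among the measured compounds shown here, the two changes are on different parts of the molecule, and no compound carries both at once among those measured.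

Compound 4 `O=S(=O)(/C=C/c1ccc(Cl)cc1Cl)Cc1ccc(Nc2ncnc3ccc(Br)cc23)cc1` has not yet been measured. It differs from compound 3 by 2,4-dichlorophenyl in place of 4-hydroxyphenyl on a double-bonded chain carbon bound to a double-bonded chain carbon, which is the same change as that from compound 2 to compound 1: the place lines read identically. The cores of compound 3 and compound 4 carry the bromo that separates compound 3 from compound 2, as described by bromo in place of hydrogen on an aromatic carbon.

On the expectation that the change behaves in compound 3 much as it did in compound 2, where it gave an 8.3-fold lower number from compound 2 to compound 1 (0.92 log units; beyond the scatter), the step from compound 3 to compound 4 is estimated at a 6.8-fold lower number from compound 3 to compound 4 (0.83 log units; beyond the scatter). The estimate rests on a single pair, so it is held loosely. Compound 4 is therefore expected to give about 4000 nM in this assay, with a likely range from 1500 nM to 12000 nM.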

Compound 4, concentration for 50% growth inhibition: 8000 nM
Compound 4: middle estimate off by 2.0-fold (0.30 log units), on the low side; low and high end bracket the measured number.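

In this assay, the change to 2,4-dichlorophenyl from 4-hydroxyphenyl on the bromo-bearing core gives a 3.4-fold lower number from compound 3 to compound 4 (0.53 log units; beyond the scatter), which is beyond the scatter and in the same direction as on the core of compound 2, and the two steps cannot be told apart: the same change on two cores in this assay, an 8.3-fold lower number (0.92 log units; beyond the scatter) from compound 2 to compound 1 and a 3.4-fold lower number (0.53 log units; beyond the scatter) from compound 3 to compound 4, 2.5-fold (0.39 log units) apart, within the scatter of two such steps. The bromo change, read on the core that carries 2,4-dichlorophenyl, gives a 1.5-fold lower number from compound 1 to compound 4 (0.18 log units; within the scatter), so compound 1 and compound 4 cannot be separated on that core, although the same change was beyond the scatter on the core of compound 2; even so, these two steps cannot be told apart either: the same change on two cores in this assay, a 3.7-fold lower number (0.57 log units; beyond the scatter) from compound 2 to compound 3 and a 1.5-fold lower number (0.18 log units; within the scatter) from compound 1 to compound 4, 2.5-fold (0.39 log units) apart, within the scatter of two such steps. Among the compounds shown here, this shows that the aryl change kept its direction on both cores and that the results fit a transfer from one core to the other, but with only one pair on each side it does not show that the size of either step is the same on both cores.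

The compounds shown leave open whether the step comes from losing the hydroxy group or from gaining the chloro groups, which a plain phenyl or a phenyl carrying a single chloro or a methoxy could help separate. They also leave open how a fluoro or a methoxy would behave in the place of the bromo.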